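The source may hold more compounds than are shown below. What is called first, only, known or untested is meant among the compounds shown, and "the series" means these compounds.

Compound 1 `O=C(CN1CCN(c2cccc(Cl)c2)CC1)N1CCN(c2nnc(-c3ccccc3)c(-c3ccccc3)n2)CC1` gives 178000 nM in an ADME assay on NIH3T3 cells (Mus musculus) for cytotoxicity, read by MTT assay, with a stated time of 24 h; on this read-out higher numbers stand for weaker inhibition and lower numbers for stronger inhibition.
Compound 2 `O=C(CN1CCN(c2ccc(Cl)cc2)CC1)N1CCN(c2nnc(-c3ccccc3)c(-c3ccccc3)n2)CC1` gives 113000 nM in this assay.
Compound 3 `Cc1ccc(-c2nnc(N3CCN(C(=O)CN4CCN(c5ccccc5Cl)CC4)CC3)nc2-c2ccc(C)cc2)cc1` gives only a limit, > 859000 nM, in this assay.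

Within the data shown here, compound 3 therefore stands at the limit of > 859000 nM in this assay, at which 1 of the 3 values shown sits, the one compound of the three for which no number, only a limit, is known. Compound 4 `Cc1ccc(-c2nnc(N3CCN(C(=O)CN4CCN(c5ccc([N+](=O)[O-])cc5)CC4)CC3)nc2-c2ccc(C)cc2)cc1` differs from it in a single place: 4-nitrophenyl in place of 2-chlorophenyl on an amine nitrogen in a ring. Among the measured compounds shown here, the only measured step, a 1.6-fold lower number from compound 1 to compound 2 (0.20 log units; within the scatter), concerns one chlorophenyl exchanged for another on the same ring nitrogen and stayed within the scatter; no measured step touches the exchange of chlorine for a nitro group. On this basis no shift beyond the scatter is expected, and compound 4 is estimated at 900000 nM (from 300000 nM to 3000000 nM), with the expected step that the limit leaves unreadable from compound 3 to compound 4 most likely leaving compound 4 at a limit as well.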

Compound 4, half-maximal inhibitory concentration: > 844000 nM
Compound 4: a limit, no number; the forecaster's own chance of this, stated with the estimate: 60%; the middle value lies beyond the limit too.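

Compound 3 and compound 4 both give only limits in this assay, so the step between them cannot be read. The compounds shown leave open whether 4-nitrophenyl in place of 2-chlorophenyl changes the value at all.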